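The compounds below may be only part of what the source reports. "The series", "measured", "known", "first", "only" and "open" are said of these compounds alone.

Compound 1 `CCCn1c(=O)c2nc(-c3cnn(Cc4cc(Cl)ccc4Cl)c3)[nH]c2n(CCC)c1=O` is the strongest of the three measured in an assay on CHO cells for displacement of a labelled ligand from adenosine receptor A1 (Homo sapiens) (on this read-out higher numbers stand for weaker inhibition and lower numbers for stronger inhibition), where compound 1 gives 190 nM. Compound 3 `CC(C)Cn1c(=O)c2nc(-c3cnn(Cc4cccc(F)c4)c3)[nH]c2n(CC(C)C)c1=O` gives 830 nM, and compound 2 `CC(C)Cn1c(=O)c2nc(-c3cnn(Cc4cccc(C(F)(F)F)c4)c3)[nH]c2n(CC(C)C)c1=O` gives 3100 nM. Among the compounds with values here, the one single-point step among them is a 3.7-fold lower number from compound 2 to compound 3 (0.57 log units; beyond the scatter), on a core with isobutyl chains rather than propyl. Compound 4 `CCCn1c(=O)c2nc(-c3cnn(Cc4cccc(Cl)c4)c3)[nH]c2n(CCC)c1=O` differs from compound 1 by hydrogen in place of chloro on an aromatic carbon, that is 2,5-dichlorophenyl to 3-chlorophenyl. Within the data shown here, no measured step removes a chloro ortho to the large group, so the change is untested here; the only guide is that smaller groups on this ring gave numbers in the same region. A modest loss is expected, a 2.1-fold higher number from compound 1 to compound 4 (0.32 log units; beyond the scatter), giving compound 4 an estimated 400 nM with a range from 150 nM to 1100 nM.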

Compound 4, inhibition constant: 31 nM
Estimate against measurement, compound 4: 13-fold (1.11 log units) above, outside the stated range (below it).
By their numbers in this assay, from the lowest: compound 4; then compound 1; then compound 3; then compound 2.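

In this assay there is a 6.1-fold lower number from compound 1 to compound 4 (0.79 log units; beyond the scatter) on replacing the chloro ortho to a large group with hydrogen, so 2,5-dichlorobenzyl to 3-chlorobenzyl on the propyl core gives stronger inhibition. This chloro is therefore not needed for inhibition at this receptor, and the ring keeps its remaining chloro. No measured evidence accounts for the gain. Open, as far as these compounds go, is whether a methoxy or an amine at this position would also give a number lower than that of compound 1, and whether 3-chlorobenzyl behaves the same way with isobutyl chains.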